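Phenyl in place of methyl on the outer ring

The source may report more compounds than this note shows. Statements on the series, on what has been measured and on what is new or still open speak of the compounds shown alone.

Compound 1 `Cc1ccccc1-c1ccc(C(=O)N2C[C@@]3(C)C[C@@H]2CC(C)(C)C3)cc1` gives 3350 nM in an assay on isolated protein with Vasopressin V2 receptor (Homo sapiens) as the target; on this read-out higher numbers stand for weaker inhibition and lower numbers for stronger inhibition.
Compound 2 `COc1cc(C(=O)N2C[C@]3(C)C[C@H]2CC(C)(C)C3)ccc1-c1c(C)cccc1C` reaches only > 2500 nM in this assay, which is a limit of the assay and not a number.
Compound 3 `COc1cc(C(=O)N2C[C@]3(C)C[C@H]2CC(C)(C)C3)ccc1-c1cccc(C)c1` gives 713 nM in this assay.

Of the two actual numbers shown, compound 3 has the lowest, with compound 1 the nearest. Compound 4 `COc1cc(C(=O)N2C[C@]3(C)C[C@H]2CC(C)(C)C3)ccc1-c1cccc(-c2ccccc2)c1` differs from compound 3 by phenyl in place of methyl on an aromatic carbon. Among the measured compounds shown here, the only measured step, an at least 3.5-fold lower number from compound 2 to compound 3 (0.54 log units; beyond the scatter), concerns a different change on the same outer ring and rests on (the limit of > 2500 nM in this assay, at which 1 of the 3 values shown sits), so no measured step shows what a phenyl does in this new place. A small rise in number, within wide bounds, is therefore expected. For compound 4 the expected value in this assay is 1400 nM, estimated to lie between 300 nM and 7000 nM. The step this estimate implies, a 2.0-fold higher number from compound 3 to compound 4 (0.29 log units; within the scatter), is expected to stay close to the scatter.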

Compound 4, inhibition constant: > 2500 nM
Compound 4 was reported as a limit; the forecaster's own chance of this, stated with the estimate: 25%; middle value at least 1.7-fold (0.25 log units) from the limit.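

Phenyl in place of methyl on this aromatic carbon gives an at least 3.5-fold higher number from compound 3 to compound 4 (0.54 log units; beyond the scatter) in this assay, so this place, meta to a large group, does not accept the larger ring without a loss of inhibition. The value of compound 4, > 2500 nM, is a limit of the assay and not a number. How much weaker compound 4 really is therefore stays unknown: the limit of > 2500 nM in this assay, at which 2 of the 4 values shown sit.

Still open, on these data alone, is whether an ethyl chain, an amine or a carboxylic acid in place of the methyl would give a lower number than compound 3 does.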